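Thiourea aryl swap on the shared core: dichlorophenyl variant

This account rests on a few compounds, and the source may have more. Where it says the series, first, only, none or still open, it means among the compounds named here.

Compound 3 `CSc1ccccc1NC(=S)N1CCc2c(sc(NC(=O)c3ccccc3Cl)c2C(N)=O)C1` gives 13800 nM in a functional assay on MKN-74 cells (Homo sapiens) for antiproliferative activity, with a stated time of 24 h (a lower number here means a stronger inhibitor, a higher number a weaker inhibitor), the second highest of the three numbers measured: compound 2 `NC(=O)c1c(NC(=O)c2ccccc2Cl)sc2c1CCN(Cc1cc(Cl)cc(Cl)c1)C2` gives 23700 nM, and compound 1 `NC(=O)c1c(NC(=O)c2ccccc2Cl)sc2c1CCN(Cc1ccccc1Cl)C2` gives 4430 nM. Relative to compound 3, the step of a 1.7-fold lower number from compound 2 to compound 3 (0.23 log units; within the scatter) lies within the scatter, whereas a 3.1-fold higher number from compound 1 to compound 3 (0.49 log units; beyond the scatter) does not. Compound 4 `NC(=O)c1c(NC(=O)c2ccccc2Cl)sc2c1CCN(C(=S)Nc1c(Cl)cccc1Cl)C2` carries 2,6-dichlorophenyl in place of 2-(methylsulfanyl)phenyl on an amide-type nitrogen. For the measured compounds named here, no measured step alters the group on this amide-type nitrogen; the nearest precedent is a change of the aryl on a saturated chain carbon bound to an amine nitrogen in a ring, a 5.3-fold higher number from compound 1 to compound 2 (0.73 log units; beyond the scatter), which is only loosely comparable. The expected step of a 1.1-fold higher number from compound 3 to compound 4 (0.04 log units; within the scatter) is therefore small, with no confident direction. Compound 4 is estimated at 15000 nM, within 5000 nM to 45000 nM.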

Compound 4, half-maximal inhibitory concentration: 4020 nM
Compound 4: middle estimate off by 3.7-fold (0.57 log units), on the high side, and the stated range ends above it.
By their numbers in this assay, from the lowest: compounds 4 and 1 (each within the scatter of the next); then compounds 3 and 2 (each within the scatter of the next).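

For the compounds shown here, on the amide-type nitrogen whose other neighbour is the thiocarbonyl carbon, the aryl group matters in this assay: 2,6-dichlorophenyl in place of 2-(methylsulfanyl)phenyl gives the first measured step at this position (a 3.4-fold lower number from compound 3 to compound 4 (0.54 log units; beyond the scatter)). With this aryl group, the thiocarbonyl-linked substituent also stands clear of the 3,5-dichlorobenzyl group (a 5.9-fold lower number from compound 2 to compound 4 (0.77 log units; beyond the scatter)), yet offers no separation from the 2-chlorobenzyl group (a 1.1-fold lower number from compound 1 to compound 4 (0.04 log units; within the scatter)). No evidence on hand accounts for these steps.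

Still open, from the compounds shown here alone, is whether an unsubstituted phenyl, a methoxyphenyl or a simple alkyl chain on this nitrogen would follow compound 4 or compound 3. Also unresolved is whether one chlorine on the phenyl ring would suffice.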